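This account rests on a few compounds, and the source may have more. Where it says the series, first, only, none or still open, it means among the compounds named here.

Compound 1 `O=C(Nc1ccc(C(F)(F)F)cc1)C1c2ccccc2CCN1C(=O)c1ccc(Cl)cc1` gives 4200 nM in a functional assay on NUGC-3 cells (Homo sapiens) for inhibition, read by sulforhodamine B assay, with a stated time of 48 h; a lower number here means a stronger inhibitor of growth, a higher number a weaker inhibitor of growth.
Compound 2 `O=C(Nc1ccccc1O)C1c2ccccc2CCN1C(=O)c1ccc(Cl)cc1` gives in this assay only the assay limit of > 10000 nM, not a number.

Compound 2 therefore stands at the limit of this assay, as the line the limit of > 10000 nM in this assay, at which 1 of the 2 values shown sits, records, and nothing more precise is known about its growth inhibition. Within the data shown here, the one measured step, an at least 2.3-fold higher number from compound 1 to compound 2 (0.37 log units; beyond the scatter), moves from a number to a limit and concerns the whole aryl group on the amide-type nitrogen, so it bears on the next change only at a distance. Compound 3 `COc1ccccc1NC(=O)C1c2ccccc2CCN1C(=O)c1ccc(Cl)cc1` differs from compound 2 by methyl in place of hydrogen on an oxygen on an aromatic ring. Among the measured compounds shown here, no measured step touches this oxygen, so the expected change is small and of uncertain direction. The expected step, an at least 1.1-fold lower number from compound 2 to compound 3 (0.04 log units; that floor lies within the scatter), leaves open whether a number or again a limit will be read. Compound 3 is estimated at 9000 nM, within 3000 nM to 25000 nM.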

Compound 3, concentration for 50% growth inhibition: 1590 nM
The estimate for compound 3 lay 5.7-fold (0.75 log units) above the measured number; measured number outside the range, below it.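

Methyl on this oxygen on an aromatic ring separates two compounds that otherwise share everything, and the change from hydroxy to methoxy matters for growth inhibition in this assay (an at least 6.2-fold lower number from compound 2 to compound 3 (0.79 log units; beyond the scatter)). The swap of the whole aryl group also reads differently now: the loss seen with 2-hydroxyphenyl does not extend to every replacement of 4-(trifluoromethyl)phenyl, since 2-methoxyphenyl gives a gain (a 2.6-fold lower number from compound 1 to compound 3 (0.42 log units; beyond the scatter)). Compound 2 holds only a limit of the assay, so the first of these steps is a floor and its true size remains unknown: the limit of > 10000 nM in this assay, at which 1 of the 3 values shown sits.

The compounds shown leave open whether a longer chain on this oxygen, such as ethoxy, would keep or extend the gain. They also leave open what an amine in place of the methoxy group would do.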